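From compound 1 to compound 4: one added methoxy

The source may report more compounds than this note shows. Statements on the series, on what has been measured and on what is new or still open speak of the compounds shown alone.

In a functional assay on HCT-15 cells (Homo sapiens) for cytotoxicity, read by colorimetric assay and MTT assay (on this read-out higher numbers stand for weaker inhibition and lower numbers for stronger inhibition), compound 1 `COc1cccc2cc(-c3ccccc3)c(O)nc12` gives 10000 nM, level with compound 2 `COc1ccc2cc(-c3ccccc3)c(O)nc2c1` at 10000 nM and compound 3 `COc1cc(OC)c2cc(-c3ccccc3)c(O)nc2c1` at 10000 nM. Compound 4 `COc1ccc(-c2cc3cccc(OC)c3nc2O)cc1` differs from compound 1 by one change: methoxy in place of hydrogen on an aromatic carbon. This is methoxy in place of hydrogen on an aromatic carbon, para to a large group. Within the data shown here, the one measured step of this kind is no change at the digits printed from compound 2 to compound 3 (within the scatter), but no measured step covers this exact place. On that single step, no change beyond the scatter is expected in this assay, in either direction. The expected step is no change at the digits printed from compound 1 to compound 4 (within the scatter). The estimate for compound 4 is 10000 nM, with an expected range of 4000 nM to 15000 nM.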

Compound 4, half-maximal inhibitory concentration: 10000 nM
Compound 4: the middle estimate sits on the measured number at the digits printed; the range from low to high includes it.
By their numbers in this assay, from the lowest: compounds 1, 2, 3 and 4 (each within the scatter of the next).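

In this assay, methoxy in place of hydrogen on an aromatic carbon, para to a large group, now has a measured step at this exact place: no change at the digits printed from compound 1 to compound 4 (within the scatter). The same change now reads alike on two cores: the same change on two cores in this assay, no change at the digits printed (within the scatter) from compound 2 to compound 3 and no change at the digits printed (within the scatter) from compound 1 to compound 4, 1.0-fold (0.00 log units) apart, within the scatter of two such steps

With all four compounds level, the series offers no group at this place that separates from the others. Going by these compounds, whether an amine, a carboxylic acid or a longer alkoxy chain in place of the methoxy would move the number of compound 4 from 10000 nM stays open.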